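A few compounds are considered here, and "the series" means these few. Any claim that something is new, unique, unknown or untested is made for them only; others in the source may bear on it.

In an ADME assay on Caco-2 cells (Homo sapiens) for inhibition, read by sulforhodamine B assay, with a stated time of 72 h (on this read-out higher numbers stand for weaker inhibition and lower numbers for stronger inhibition), the measured compounds read as follows.

Compound 1 (`CCCNC(=C\C(=O)/C=C/c1ccc(O)c(OC)c1)/C=C/c1ccc(O)c(OC)c1`) gives > 25000 nM, a limit of the assay.
Compound 2 (`C=CCNC(=C\C(=O)/C=C/c1ccc(O)c(OC)c1)/C=C/c1ccc(O)c(OC)c1`) gives > 25000 nM, a limit of the assay.
Compound 3 (`CCC(C)NC(=C\C(=O)/C=C/c1ccc(O)cc1)/C=C/c1ccc(O)cc1`) gives > 25000 nM, a limit of the assay.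

None of the three has yielded a number, and compound 2 therefore stands only at a limit, like the other two. The next compound, compound 4 (`COc1cc(/C=C/C(=O)/C=C(/C=C/c2ccc(O)c(OC)c2)NCC(C)C)ccc1O`), has isopropyl in place of vinyl on a saturated chain carbon bound to an amine nitrogen, so that allyl gives way to isobutyl on the allylamino side chain: isopropyl in place of vinyl on a saturated chain carbon bound to an amine nitrogen.

Among the compounds with values here, one measured step touches this same position: a step that the two limits leave unreadable from compound 1 to compound 2. It shows no size that could be carried over to the new change. Within the data shown here, compound 3 adds no step of its own. What remains is the overall picture, (the limit of > 25000 nM in this assay, at which 3 of the 3 values shown sit), and on that basis compound 4 is expected to stay in the same region, with no step beyond the scatter anticipated. The expected size of the change is a step that the limit leaves unreadable from compound 2 to compound 4, and this is an estimate resting on limits alone. For compound 4 the estimated value is 30000 nM, with an expected range from 15000 nM to 60000 nM.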

Compound 4, half-maximal inhibitory concentration: > 25000 nM
Compound 4 was reported as a limit (the forecaster's own chance of this, stated with the estimate: 80%); the middle value is on the limit's open side.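

In this assay compound 4 gives > 25000 nM, a limit of the assay. The steps to compound 4 from compound 1 and from compound 2 cannot be read, so no new step emerges: the limit of > 25000 nM in this assay, at which 4 of the 4 values shown sit.

The compounds shown leave open how they rank against one another and what any change in the amine side chain does to the read-out.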